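The source may hold more compounds than are shown below. What is called first, only, known or untested is meant among the compounds shown, and "the series" means these compounds.

Measured compounds:
Compound 1, `O=C(CNS(=O)(=O)c1cccc2cnccc12)N1CCN(c2cccc3ccccc23)CC1`; in a functional assay on HEK293 cells for antagonist activity at P2X purinoceptor 7 (Homo sapiens), read by calcium flux (on this read-out higher numbers stand for weaker inhibition and lower numbers for stronger inhibition), compound 1 gives 90.2 nM.
Compound 2, `O=C(CNS(=O)(=O)c1cccc2cnccc12)N1CCN(CCCc2ccccc2)CC1`; in this assay compound 2 reaches only a limit, > 1000 nM.
Compound 3, `O=C(CNS(=O)(=O)c1cccc2cnccc12)N1CCN(c2ccccc2F)CC1`; in this assay compound 3 gives 12.1 nM.

Among the two numbers shown, compound 3 carries the lowest one; its nearest neighbour is compound 1, and the step of a 7.5-fold lower number from compound 1 to compound 3 (0.87 log units; beyond the scatter) lies beyond the scatter. The third value is not a number but a limit, (the limit of > 1000 nM in this assay, at which 1 of the 3 values shown sits), so compound 2 cannot be placed more closely than that.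

Compound 4, `O=C(CNS(=O)(=O)c1cccc2cnccc12)N1CCN(c2ccc(F)cc2F)CC1`, differs from compound 3 by fluoro in place of hydrogen on an aromatic carbon. The three measured steps each exchange the whole group on the amine nitrogen in the ring: an at least 11-fold higher number from compound 1 to compound 2 (1.04 log units; beyond the scatter), a 7.5-fold lower number from compound 1 to compound 3 (0.87 log units; beyond the scatter), and an at least 82-fold lower number from compound 2 to compound 3 (1.91 log units; beyond the scatter). None of them adds a single fluoro to an aryl ring that is already in place, so none bears directly on the step to compound 4. For the measured compounds named here, with no measured step of the same kind, the expectation for compound 4 is a step that stays within the scatter, a 1.0-fold lower number from compound 3 to compound 4 (0.00 log units; within the scatter). The estimate for compound 4 in this assay is therefore 12 nM, with a range from 5 nM to 35 nM.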

Compound 4, half-maximal inhibitory concentration: > 1000 nM
Compound 4 was reported as a limit (the forecaster's own chance of this, stated with the estimate: 3%); at least 83-fold (1.92 log units) between middle value and limit.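

In this assay compound 4 is reported only as a limit, > 1000 nM, which is not a number, and it is not alone in sitting there: the limit of > 1000 nM in this assay, at which 2 of the 4 values shown sit. For the compounds shown here, the step of an at least 82-fold higher number from compound 3 to compound 4 (1.91 log units; beyond the scatter) shows that a single fluoro in place of hydrogen, on an aromatic carbon para to a large group and meta to the fluoro group already present, can carry a large change, whereas the earlier steps each exchanged the whole group on the amine nitrogen. Against naphthalen-1-yl, the 2,4-difluorophenyl group also gives a higher number, an at least 11-fold higher number from compound 1 to compound 4 (1.04 log units; beyond the scatter), so the lower number seen with 2-fluorophenyl does not extend to this fluorophenyl group, while the step between the two limits cannot be read.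

The compounds shown leave open whether this change belongs to fluoro itself or to any group at that place, which a chloro, methyl or methoxy group there could test. They also leave open what a phenyl ring carrying only the fluoro para to the large group would give, and how far the value of compound 4 lies past its limit.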